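A Trifluoromethoxy Swap Carried to a Second Core

A few compounds are considered here, and "the series" means these few. Any claim that something is new, unique, unknown or untested is made for them only; others in the source may bear on it.

This account concerns three measured lactones and one that awaits measurement. Compound 1 `COc1ccccc1C[C@H]1C(=O)OC[C@@H]1Cc1ccccc1` was tested in a functional assay on HL-60 cells (Homo sapiens) for cytotoxicity, read by WST assay, with a stated time of 48 h (on this read-out higher numbers stand for an effect only at larger amounts of compound and lower numbers for an effect already at smaller amounts), and gave 79000 nM. Compound 2 `O=C1OC[C@H](Cc2ccccc2)[C@H]1Cc1ccccc1OC(F)(F)F` differs from it by one change, (trifluoromethyl in place of methyl on an oxygen on an aromatic ring), and in this assay compound 2 gave 39000 nM. That change produced a 2.0-fold lower number from compound 1 to compound 2 (0.31 log units; beyond the scatter).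

Compound 3 `COc1ccc(C[C@H]2C(=O)OC[C@@H]2Cc2ccccc2)cc1` carries the same atoms as compound 1 joined differently; the difference between the two cores is not broken down here. In this assay compound 3 gave 67000 nM, which sits within the usual scatter of the number for compound 1 and also within the scatter of the number for compound 2, so no order among the three can be read from it.

Compound 4 `O=C1OC[C@H](Cc2ccccc2)[C@H]1Cc1ccc(OC(F)(F)F)cc1` has not yet been measured. It stands to compound 3 as compound 2 stands to compound 1: trifluoromethyl in place of methyl on an oxygen on an aromatic ring, the place being described in the same words in both cases, so it is the same change applied to a second core. Among the compounds shown this change appears twice in all, once measured and once pending.

For the measured compounds named here, the expectation for compound 4 rests on the single measured instance, the step from compound 1 to compound 2, and therefore on compound 3 with its value of 67000 nM the same step is expected, namely a 1.9-fold lower number from compound 3 to compound 4 (0.28 log units; within the scatter). On that basis compound 4 is estimated to give 35000 nM in this assay, with a range from 15000 nM to 80000 nM to allow for the scatter and for the fact that one prior example is a thin basis.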

Compound 4, half-maximal effective concentration: 27000 nM
Compound 4: middle estimate off by 1.3-fold (0.11 log units), on the high side, and the stated range covers the measured number.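

In this assay, trifluoromethyl in place of methyl on an oxygen on an aromatic ring gave a 2.5-fold lower number from compound 3 to compound 4 (0.39 log units; beyond the scatter), so the second core moved in the same direction as the first. Set beside the earlier step, the two agree in size as far as these data can tell: the same change on two cores in this assay, a 2.0-fold lower number (0.31 log units; beyond the scatter) from compound 1 to compound 2 and a 2.5-fold lower number (0.39 log units; beyond the scatter) from compound 3 to compound 4, 1.2-fold (0.09 log units) apart, within the scatter of two such steps. For the compounds shown here, this shows that, across these two pairs, the change carried over from the core of compound 1 to the core of compound 3 with its effect intact, but it rests on only two modest steps in a single cell assay and shows neither why the number falls nor that the change would behave alike on any further core.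

The compounds shown carry only methoxy or trifluoromethoxy as the changed group, which leaves open whether a hydroxyl, an ethoxy, a chlorine or a longer alkoxy chain in that place would give a similar step. All four compounds are also lactones, so they leave open whether the same change would hold if an amide took the place of the lactone.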